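Swapping the aryl group on compound 2

The source may hold more compounds than are shown below. What is called first, only, known or untested is meant among the compounds shown, and "the series" means these compounds.

Two compounds have numbers in a functional assay on A549 cells (Homo sapiens) for antiproliferative activity, read by MTT assay, with a stated time of 72 h; a higher number here means a weaker inhibitor, a lower number a stronger inhibitor. Compound 1 `CNC(=O)c1cc(Oc2ccc(NC(=O)c3cc4cccnc4n(-c4ccc(C(F)(F)F)cc4Cl)c3=O)cc2)ccn1` gives 2090 nM in this assay, whereas compound 2 `CCCNC(=O)c1cc(Oc2ccc(NC(=O)c3cc4cccnc4n(-c4ccc(Br)cc4)c3=O)cc2)ccn1` gives 150 nM. Compound 2 therefore stands with the lowest number of the two, and the gap to compound 1 is well beyond the usual scatter, so compound 2 is the stronger inhibitor of the pair.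

Compound 3 `CCCNC(=O)c1cc(Oc2ccc(NC(=O)c3cc4cccnc4n(-c4ccc(C(F)(F)F)cc4Cl)c3=O)cc2)ccn1` has not yet been measured. It differs from compound 2 in one place: 2-chloro-4-(trifluoromethyl)phenyl in place of 4-bromophenyl on an aromatic nitrogen. Compound 1 differs from compound 2 in more than one place, so its weaker result cannot be tied to the aryl group alone; still, compound 1 is the only other point of reference, and it carries the same aryl group that enters in compound 3.

On that basis a step toward a higher number is expected from compound 2 to compound 3, of size a 3.3-fold higher number from compound 2 to compound 3 (0.52 log units; beyond the scatter), though a change within the scatter cannot be excluded. Compound 3 is accordingly estimated at 500 nM in this assay, with a plausible range from 150 nM to 2000 nM.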

Compound 3, half-maximal inhibitory concentration: 1250 nM
Estimate against measurement, compound 3: 2.5-fold (0.40 log units) below, and the stated range covers the measured number.
By their numbers in this assay, from the lowest: compound 2; then compounds 3 and 1 (each within the scatter of the next).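

On the aromatic nitrogen of the shared core, the aryl group matters in this assay: putting 2-chloro-4-(trifluoromethyl)phenyl in place of 4-bromophenyl gives a clear loss of activity (an 8.3-fold higher number from compound 2 to compound 3 (0.92 log units; beyond the scatter)), a step beyond the scatter. Compound 1 and compound 2 differ in more than one place, so their gap could not be assigned to either change, whereas this single-change comparison isolates the effect of the aryl group. The other change, ethyl in place of hydrogen on a saturated chain carbon bound to an amide-type nitrogen, gives a step within the scatter (a 1.7-fold lower number from compound 1 to compound 3 (0.22 log units; within the scatter)), so with this aryl group in place it shows no real effect on activity.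

The entering group differs from 4-bromophenyl in more than one feature, and the compounds shown leave open whether the loss follows the chlorine, the trifluoromethyl or their combination, a question that 2-chlorophenyl and 4-(trifluoromethyl)phenyl analogues would help to answer. Nothing in the data shown explains why this aryl change weakens activity.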